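Working notes on compound 4 before its cytotoxicity number

The source may report more compounds than this note shows. Statements on the series, on what has been measured and on what is new or still open speak of the compounds shown alone.

Of the compounds shown here, three have been measured. Compound 1 `Cc1ccc(NC(=O)CS(=O)(=O)c2nccc(Oc3c(C)cc(C#N)cc3C)n2)cc1` gives 7490 nM in an ADME assay on MT4 cells (Homo sapiens) for cytotoxicity, read by MTT assay, with a stated time of 4 days; a higher number here means that more compound is tolerated, a lower number that less compound is tolerated. Compound 2 `Cc1ccc(NC(=O)CS(=O)(=O)c2nccc(Oc3c(C)cc(C#N)cc3C)n2)cc1C` gives 13900 nM in this assay. Compound 3 `Cc1cc(C#N)cc(C)c1Oc1ccnc(S(=O)(=O)CC(=O)Nc2ccc(Cl)cc2Cl)n1` gives 10400 nM in this assay. On the bare numbers compound 2 sits at the top of the three, but the step of a 1.9-fold higher number from compound 1 to compound 2 (0.27 log units; within the scatter) and the step of a 1.3-fold lower number from compound 2 to compound 3 (0.13 log units; within the scatter) both fall within the scatter, so no real order among the three can be claimed.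

Compound 4 `Cc1cc(C#N)cc(C)c1Oc1ccnc(S(=O)(=O)CC(=O)Nc2ccc(C#N)cc2)n1` has not been measured. It differs from compound 2 by 4-cyanophenyl in place of 3,4-dimethylphenyl on an amide-type nitrogen. Two measured steps change the group on that same amide-type nitrogen: a 1.4-fold higher number from compound 1 to compound 3 (0.14 log units; within the scatter) and a 1.3-fold lower number from compound 2 to compound 3 (0.13 log units; within the scatter), each within the scatter. The remaining step, a 1.9-fold higher number from compound 1 to compound 2 (0.27 log units; within the scatter), is also within the scatter. Among the compounds with values here, none of the measured steps brings in 4-cyanophenyl, so there is no direct precedent for a nitrile there; what is known is that changes on this nitrogen have so far moved nothing beyond the scatter. The step of a 1.4-fold lower number from compound 2 to compound 4 (0.14 log units; within the scatter) is therefore expected to stay within the scatter, with no direction favoured. Compound 4 is estimated at 10000 nM, with a range from 4000 nM to 25000 nM.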

Compound 4, half-maximal cytotoxic concentration: >= 6010 nM
Compound 4: only a limit was reported; the forecaster's own chance of this, stated with the estimate: 5%; the middle value is on the limit's open side.
By their numbers in this assay, from the lowest: compounds 1, 3 and 2 (each within the scatter of the next).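

In this assay compound 4 gives >= 6010 nM, which is a limit of the assay and not a number, so its steps from compound 1, compound 2 and compound 3 cannot be read. The compounds shown leave open whether 4-cyanophenyl on the amide-type nitrogen keeps compound 4 within the scatter of these three compounds or takes it beyond.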